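Adding a sulfanyl group to compound 2

The source may report more compounds than this note shows. Statements on the series, on what has been measured and on what is new or still open speak of the compounds shown alone.

Compound 1 `O=C(Nc1nc2ccccc2s1)c1ccc(OC(F)F)c(OCC2CC2)c1`: 594 ng.h/mL
Compound 2 `O=C(Nc1ccc2ncsc2c1)c1ccc(OC(F)F)c(OCC2CC2)c1`: 892 ng.h/mL

Within the data shown here, in an ADME assay on the whole organism (strain Sprague-Dawley) for pharmacokinetics, with Rattus norvegicus as the target, read by HPLC, at a dose of 1 mg/kg by the subcutaneous route (a lower number here means less compound in the circulation, a higher number more compound in the circulation at the dose given), compound 2 cannot be told apart from compound 1, the only other compound measured: the data show a 1.5-fold higher number from compound 1 to compound 2 (0.18 log units; within the scatter). Compound 3 `O=C(Nc1ccc2nc(S)sc2c1)c1ccc(OC(F)F)c(OCC2CC2)c1` keeps all of compound 2 except for one change, sulfanyl in place of hydrogen on an aromatic carbon. Among the measured compounds shown here, the one measured step bears on this only loosely, since it swapped 1,3-benzothiazol-6-yl for 1,3-benzothiazol-2-yl on an amide-type nitrogen and involved no sulfanyl group. The data therefore point in no direction, and no step beyond the scatter is expected. The estimated outcome is a 1.2-fold lower number from compound 2 to compound 3 (0.08 log units; within the scatter). With so little to go on, the range must stay wide. For compound 3 the expected value is 750 ng.h/mL, with an estimated range of 280 ng.h/mL to 2000 ng.h/mL.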

Compound 3, area under the concentration-time curve: 622 ng.h/mL
Beside the measured number, compound 3's estimate is 1.2-fold (0.08 log units) above it, within the range that was stated.
By their numbers in this assay, from the lowest: compounds 1, 3 and 2 (each within the scatter of the next).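

Compound 3 shows that the aromatic carbon next to the ring nitrogen and next to the ring sulfur can carry a sulfanyl group in place of hydrogen with no difference that stands out from the scatter in this assay (a 1.4-fold lower number from compound 2 to compound 3 (0.16 log units; within the scatter)). Among these compounds, compound 2 has only hydrogen on this carbon, so this is the first reading of a group added there to that compound. No measurement here bears on what lies behind this result.

The compounds shown leave open whether a methyl group, an amine or a methoxy group on this same carbon would also stay within the scatter. A single added group on a single carbon also leaves open how changes elsewhere on the shared core would read.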